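The source may report more compounds than this note shows. Statements on the series, on what has been measured and on what is new or still open speak of the compounds shown alone.

Measured so far:
compound 1, `Clc1ccc(-c2csc(N/N=C/c3ccccc3)n2)cc1`: 40%
compound 2, `COc1ccc(/C=N/Nc2nc(-c3ccc(Cl)cc3)cs2)cc1OC`: 40%

Both compounds were run in an in vitro assay on BTI-TN-5B1-4 cells for inhibition of Amine oxidase [flavin-containing] B (Homo sapiens), read by fluorescence, with a stated time of 15 min, tested at 100 uM; a higher number here means more inhibition at the concentration tested (going by the name of the read-out), a lower number less inhibition. Compound 1 gives 40% in this assay, and compound 2 gives 40%. The two values are level at the digits reported; the difference between them lies within the scatter of this measurement, so no order can be read into them. Among the compounds with values here, no pair of compounds differing in one place has been measured, so nothing is yet known about how a single structural change moves the read-out.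

The next compound is compound 3, `COc1ccc(/C=N/Nc2nc(-c3ccc(Cl)cc3)cs2)cc1`, which is to be measured in this assay. It differs from compound 2 by hydrogen in place of methoxy on an aromatic carbon. Within the data shown here, with no measured step of this kind available, the step of no change at the digits printed from compound 2 to compound 3 (within the scatter) is expected to be small, no larger than the scatter, and in neither direction in particular; the two measured values give no lean either way. Compound 3 is therefore expected to give 40% in this assay, within an estimated range of 25% to 55%.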

Compound 3, a percentage reported as inhibition, at one concentration (the size of the read-out at that concentration, not a potency): 40%
Compound 3: the middle estimate sits on the measured number at the digits printed; the measured number falls inside the stated range.
By their numbers in this assay, from the lowest: compounds 1, 2 and 3 (each within the scatter of the next).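

In this assay, the series now has its first steps that differ in one place, and both are flat: with hydrogen in place of the methoxy that sits ortho to a methoxy group and meta to a large group, the result is no change at the digits printed from compound 2 to compound 3 (within the scatter), and with methoxy in place of hydrogen on an aromatic carbon, it is no change at the digits printed from compound 1 to compound 3 (within the scatter). Within these three compounds, then, the read-out does not separate hydrogen from methoxy at either of these places, whereas the earlier pair differed in more than one place and could not show this for a single change. Nothing measured here bears on why the read-out stays level.

From the compounds shown here alone, these steps cover only hydrogen and methoxy on this ring, so it remains open whether an amine, a carboxylic acid or a longer alkoxy chain on the same aromatic carbon would move the read-out beyond the scatter. The chlorine shared by all three compounds is also untested as a point of change, and a percentage read at one concentration shows for compounds 1, 2 and 3 only the size of the effect at that concentration.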